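The compounds below may be only part of what the source reports. "The series", "measured", "known", "first", "only" and "open" are said of these compounds alone.

Measured compounds, cytotoxicity on rat L6 cells:

compound 1 `OC[C@H]1O[C@@H](n2cnc3c(NC4CCCC4)nc(NC4CCCC4)nc32)[C@H](O)[C@@H]1O` — 97300 nM
compound 2 `OC[C@H]1O[C@@H](n2cnc3c(Nc4ccccc4)nc(NC4CCCC4)nc32)[C@H](O)[C@@H]1O` — 36300 nM

In an ADME assay on L6 cells (Rattus norvegicus) for cytotoxicity (on this read-out higher numbers stand for weaker inhibition and lower numbers for stronger inhibition), compound 1 gives 97300 nM. In this assay, going by the values given here, compound 2 gives 36300 nM, the lowest of the two numbers so far; the only measured step is a 2.7-fold lower number from compound 1 to compound 2 (0.43 log units; beyond the scatter), a modest move beyond the scatter.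

Compound 3 `OC[C@H]1O[C@@H](n2cnc3c(Nc4ccccc4)nc(NCCOCc4ccccc4)nc32)[C@H](O)[C@@H]1O` is not yet measured. It keeps the shared core of compound 2 and differs in one place: 2-(benzyloxy)ethyl in place of cyclopentyl on a nitrogen on an aromatic ring. Among the compounds with values here, the only step that bears on this is a 2.7-fold lower number from compound 1 to compound 2 (0.43 log units; beyond the scatter), in which a cyclopentyl on a nitrogen on an aromatic ring also gave way to a group carrying an aromatic ring, at a modest size. The present change is larger in atom count and sits at the other nitrogen, so the parallel is loose; a step of similar size, toward a lower number, is expected, but a result within the scatter would not surprise. The step from compound 2 to compound 3 is estimated at a 1.8-fold lower number from compound 2 to compound 3 (0.26 log units; within the scatter). For compound 3 the expected value is 20000 nM, with a range from 7000 nM to 60000 nM.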

Compound 3, half-maximal inhibitory concentration: 53800 nM
The estimate for compound 3 lay 2.7-fold (0.43 log units) below the measured number; the measured number falls inside the stated range.
By their numbers in this assay, from the lowest: compounds 2, 3 and 1 (each within the scatter of the next, the first and the last beyond it).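

In this assay, the step of a 1.5-fold higher number from compound 2 to compound 3 (0.17 log units; within the scatter) lies within the scatter, so on this nitrogen on an aromatic ring, 2-(benzyloxy)ethyl, with 10 heavy atoms, one six-membered aromatic ring and 1 hydrogen-bond acceptor, reads the same as cyclopentyl, with 5 heavy atoms and neither feature. Going by these compounds alone, the only earlier step, a 2.7-fold lower number from compound 1 to compound 2 (0.43 log units; beyond the scatter), lies beyond the scatter but sits at a different place on the shared core, so an incoming aromatic ring does not give a shift beyond the scatter in every position of this series. Nothing available accounts for this result at the level of mechanism.

The compounds shown leave open whether the oxygen or the aromatic ring of the chain matters at this nitrogen, which a methoxyethyl chain or a plain pentyl chain would separate. Also open, on these data alone, is how a chain ending in an amine or a carboxylic acid would read in this assay at the same place.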